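Succinyl Amide in Place of Ethyl on the Amine

The source may report more compounds than this note shows. Statements on the series, on what has been measured and on what is new or still open speak of the compounds shown alone.

Compound 1 `CCCCCCCCCCCCCCC(N)CO`: 7000 nM
Compound 2 `CCCCCCCCCCCCCCC(COCc1ccccc1)NCC`: 6000 nM

In a functional assay on Jurkat cells (Homo sapiens) for inhibition (on this read-out higher numbers stand for weaker inhibition and lower numbers for stronger inhibition), compound 2 gives 6000 nM, and compound 1 gives 7000 nM; these two numbers lie within the usual scatter of each other, so neither stands apart. Compound 3 `CCCCCCCCCCCCCCC(COCc1ccccc1)NC(=O)CCC(=O)O` differs from compound 2 by (2-carboxyethyl)carbonyl in place of ethyl on an amine nitrogen. Going by the values given here, no measured pair shows a change of this kind, so the size of the step is uncertain. A modest step toward weaker inhibition is expected, a 2.0-fold higher number from compound 2 to compound 3 (0.30 log units; within the scatter). Compound 3 is estimated in this assay at 12000 nM, with a range from 4000 nM to 40000 nM.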

Compound 3, half-maximal inhibitory concentration: 30000 nM
Compound 3: middle estimate off by 2.5-fold (0.40 log units), on the low side, within the range that was stated.
By their numbers in this assay, from the lowest: compounds 2 and 1 (each within the scatter of the next); then compound 3.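

In this assay, going by these compounds alone, (2-carboxyethyl)carbonyl in place of ethyl on an amine nitrogen gives a 5.0-fold higher number from compound 2 to compound 3 (0.70 log units; beyond the scatter), the only step here and one toward weaker inhibition. This position is therefore not indifferent to what it carries, and this change costs inhibition. Nothing given here accounts for the size of the step.

The compounds shown leave open whether the loss goes with the carboxylic acid or with the amide carbonyl. A simple acetyl amide or the methyl ester of the same chain would separate the two.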